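Replacing 3-methylbenzyl with methyl on the nitrogen

The source may hold more compounds than are shown below. What is called first, only, known or untested is meant among the compounds shown, and "the series" means these compounds.

In an ADME assay on L6 cells (Rattus norvegicus) for cytotoxicity, read by resazurin assay, with a stated time of 70 h (a higher number here means a weaker inhibitor, a lower number a stronger inhibitor), compound 1 (`CC(=O)Oc1ccc2c(c1)C(C)=CC(C)(C)N2Cc1ccc(C)cc1`) gives 21000 nM, compound 2 (`CC(=O)Oc1ccc2c(c1)C(C)=CC(C)(C)N2Cc1cccc(Cl)c1`) gives 29000 nM and compound 3 (`CC(=O)Oc1ccc2c(c1)C(C)=CC(C)(C)N2Cc1cccc(C)c1`) gives 28000 nM, so compound 3 stands within the scatter of both. Compound 4 (`CC(=O)Oc1ccc2c(c1)C(C)=CC(C)(C)N2C`) has hydrogen in place of 3-methylphenyl on a saturated chain carbon bound to a nitrogen on an aromatic ring in a ring. The nearest measured steps (a 1.4-fold higher number from compound 1 to compound 2 (0.14 log units; within the scatter), a 1.3-fold higher number from compound 1 to compound 3 (0.12 log units; within the scatter), a 1.0-fold lower number from compound 2 to compound 3 (0.02 log units; within the scatter)) are small, but each keeps the aromatic ring, so none sizes its loss. A higher number is only tentatively expected, and the estimated move is a 2.0-fold higher number from compound 3 to compound 4 (0.29 log units; within the scatter) on present data. Compound 4 is estimated at 55000 nM (expected range 20000 nM to 150000 nM).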

Compound 4, half-maximal inhibitory concentration: 41000 nM
Beside the measured number, compound 4's estimate is 1.3-fold (0.13 log units) above it, and the stated range covers the measured number.
By their numbers in this assay, from the lowest: compounds 1, 3, 2 and 4 (each within the scatter of the next).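

In this assay, going from 3-methylbenzyl to methyl on the nitrogen leaves every step within the scatter (a 1.5-fold higher number from compound 3 to compound 4 (0.17 log units; within the scatter); a 1.4-fold higher number from compound 2 to compound 4 (0.15 log units; within the scatter); a 2.0-fold higher number from compound 1 to compound 4 (0.29 log units; within the scatter)). At this position, then, the aromatic ring is not required for a number in this range, and methyl sits level with all three benzyl-type groups. No evidence on the cause accompanies this result.

Still open, on these data alone, is whether a longer chain ending in an amine or a carboxylic acid on this nitrogen would take the number beyond the scatter.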